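Valine to serine-benzyl ester on the bicyclic core

A few compounds are considered here, and "the series" means these few. Any claim that something is new, unique, unknown or untested is made for them only; others in the source may bear on it.

Two esters of the shared core are measured. In an assay for inhibition of kallikrein-7 (Homo sapiens), read by FRET, with a stated time of 5 min (on this read-out higher numbers stand for weaker inhibition and lower numbers for stronger inhibition), compound 1 (`CC(C)(C)OC(=O)N1CCC[C@H]1C(=O)O[C@@H]1CO[C@H]2[C@@H]1OC[C@H]2OCc1ccccc1`) gives 24400 nM, while compound 2 (`CC(C)[C@@H](NC(=O)OC(C)(C)C)C(=O)O[C@@H]1CO[C@H]2[C@@H]1OC[C@H]2OCc1ccccc1`) gives 239000 nM, the higher of the two numbers and beyond the scatter from compound 1. Compound 3 (`CC(C)(C)OC(=O)N[C@H](COCc1ccccc1)C(=O)O[C@@H]1CO[C@H]2[C@@H]1OC[C@H]2OCc1ccccc1`) carries (benzyloxy)methyl in place of isopropyl on a saturated chain carbon bound to an amide-type nitrogen and a carbonyl carbon. Within the data shown here, no measured pair shows this change; a modest move toward stronger inhibition is expected, possibly not beyond the scatter. Compound 3 is expected to give 120000 nM in this assay, within 40000 nM to 400000 nM. The expected step is a 2.0-fold lower number from compound 2 to compound 3 (0.30 log units; within the scatter).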

Compound 3, half-maximal inhibitory concentration: 16000 nM
The estimate for compound 3 lay 7.5-fold (0.88 log units) above the measured number; measured number below the stated range.
By their numbers in this assay, from the lowest: compounds 3 and 1 (each within the scatter of the next); then compound 2.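

In this assay, among these compounds, (benzyloxy)methyl in place of isopropyl on a saturated chain carbon bound to an amide-type nitrogen and a carbonyl carbon gives a 15-fold lower number from compound 2 to compound 3 (1.17 log units; beyond the scatter), the first single-place step. The value at this position therefore depends strongly on the group carried there, and the larger entering group, with its aromatic ring and oxygen, is tolerated. No measurement shown accounts for the step. As far as these compounds go, whether the ring or the oxygen carries the step stays open. A plain benzyl group, an amine or a carboxylic acid at this position remains to be read.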